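Nitro in place of methoxy: from compound 3 to compound 4

This account rests on a few compounds, and the source may have more. Where it says the series, first, only, none or still open, it means among the compounds named here.

Compound 1 (`COc1ccc(/C=C(\C)C(=O)/C=C/c2ccccc2)cc1`) reads 44000 nM in an ADME assay on LLC-MK2 cells (Macaca mulatta) for cytotoxicity, read by MTT assay, with a stated time of 48 h (on this read-out higher numbers stand for lower toxicity in this test and lower numbers for higher toxicity in this test), and compound 2 (`COc1ccc(/C=C/C(=O)/C(C)=C/c2ccc(OC)cc2)cc1`) reads 75000 nM there, while compound 3 (`COc1ccc(/C=C(\C)C(=O)/C=C/c2ccc([N+](=O)[O-])cc2)cc1`) reads 20100 nM there, the lowest of the three. Compound 4 (`C/C(=C\c1ccc([N+](=O)[O-])cc1)C(=O)/C=C/c1ccc([N+](=O)[O-])cc1`) differs from compound 3 by a single exchange, nitro in place of methoxy on an aromatic carbon, para to a large group. The same exchange occurs once among the measured compounds and gave a 3.7-fold lower number from compound 2 to compound 3 (0.57 log units; beyond the scatter) for that pair. Nitro in place of hydrogen gave a 2.2-fold lower number from compound 1 to compound 3 (0.34 log units; beyond the scatter) in the same direction, whereas methoxy in place of hydrogen gave a 1.7-fold higher number from compound 1 to compound 2 (0.23 log units; within the scatter) without leaving the scatter. Each exchange rests on one pair, and in compound 4 it falls at another place in the molecule, so a modest fall in this assay is expected rather than a large one. An estimated step of a 2.5-fold lower number from compound 3 to compound 4 (0.40 log units; beyond the scatter) is therefore expected here. Compound 4 is expected at about 8000 nM within a range of 3000 nM to 19000 nM on this estimate.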

Compound 4, half-maximal cytotoxic concentration: 32500 nM
Compound 4: the middle estimate sits 4.1-fold (0.61 log units) below what was measured; the measured number lies above the stated range.
By their numbers in this assay, from the lowest: compounds 3, 4, 1 and 2 (each within the scatter of the next, the first and the last beyond it).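

In this assay, nitro in place of methoxy on an aromatic carbon, para to a large group, gives (a 1.6-fold higher number from compound 3 to compound 4 (0.21 log units; within the scatter)) at this position, so this test does not separate the two compounds. The same exchange at the other place in the molecule gave (a 3.7-fold lower number from compound 2 to compound 3 (0.57 log units; beyond the scatter)), and the fall seen for that pair therefore does not carry over to this position. Nothing given here accounts for the difference between the two pairs.

The compounds shown leave open whether another group on this aromatic carbon, such as an amine or a carboxylic acid, would give a step beyond the scatter. With one pair at each place, they also leave open how far either step would hold in other pairs.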